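A few compounds are considered here, and "the series" means these few. Any claim that something is new, unique, unknown or untested is made for them only; others in the source may bear on it.

Working notes on the series. The three measured compounds share a core carrying an octyl chain; compound 1 `CCCCCCCCc1ccc(CC[C@@H]2CCCN2)cc1` gives 63% in a functional assay on FL5.12 cells (Mus musculus), read by flow cytometry, with a stated time of 3 h, tested at 10 uM (on this read-out higher numbers stand for a stronger effect at the one concentration tested and lower numbers for a weaker effect), compound 2 `CCCCCCCCc1ccc(C(C[C@@H]2CCCN2)OC)cc1` gives 58%, and compound 3 `CCCCCCCCc1ccc(C(=O)C[C@H]2C[C@H](CO)CN2)cc1` gives 60%. Compound 3 stands with its number alongside those of compound 1 and compound 2, all three within the scatter of one another, so no order among them can be read. Within the data shown here, the one step that differs in a single place, a number 5 percentage points lower from compound 1 to compound 2 (within the scatter), concerns a methoxy in place of hydrogen on a saturated chain carbon bound to an aromatic carbon and a saturated chain carbon, and it stayed within the scatter.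

Compound 4 `CCCCCCCCc1ccc(C(=O)CC[C@@H]2C[C@@H](O)CN2)cc1` has the same atoms as compound 3 joined differently: a group of 7 heavy atoms (5 carbon, 1 nitrogen, 1 oxygen; one five-membered non-aromatic ring with 1 hetero atom) in place of a group of 7 heavy atoms (5 carbon, 1 nitrogen, 1 oxygen; one five-membered non-aromatic ring with 1 hetero atom), on a saturated chain carbon bound to a carbonyl carbon. Among the measured compounds shown here, no measured step touches this part of the molecule; the only measured step, from compound 1 to compound 2, sits elsewhere and was within the scatter. Nothing in the data therefore points to a step beyond the scatter in this assay in either direction, and the expected step from compound 3 to compound 4 is a number 2 percentage points lower from compound 3 to compound 4 (within the scatter). Compound 4 is accordingly estimated at 58%, with a range from 45% to 70%.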

Compound 4, a percentage reported as activity, at one concentration (the size of the read-out at that concentration, not a potency): 52%
Beside the measured number, compound 4's estimate is 6 percentage points above it; measured number inside the range.
By their numbers in this assay, from the lowest: compounds 4, 2, 3 and 1 (each within the scatter of the next, the first and the last beyond it).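

On a saturated chain carbon bound to a carbonyl carbon, the (4-hydroxypyrrolidin-2-yl)methyl group takes the place of a group with the same atoms, giving a number 8 percentage points lower from compound 3 to compound 4 (within the scatter) in this assay. Among these compounds, this is the first measured step at this place, and it shows that rejoining these atoms, with the count of hydrogen-bond donors and acceptors and the net charge unchanged, gives no change that can be read at the one concentration tested. No measurement shown bears on the origin of the printed difference, so the step stands as an observation only.

The compounds shown leave open whether a carboxylic acid or a primary amine in place of the hydroxyl group of compound 4 would give a read-out beyond the scatter of compound 4, and the same question holds for a longer chain in place of the octyl chain. They also leave open how compound 3 and compound 4 would compare across a range of concentrations, as a single-concentration read-out gives no potency.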